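Series notes: from compound 3 to compound 4

This account rests on a few compounds, and the source may have more. Where it says the series, first, only, none or still open, it means among the compounds named here.

Measured so far:
compound 1 `N#CC1=C(NCN2CCCC2)N(c2ccccc2)C(=O)N2CCCCC(N3CCCC3)C12` — 35.3%
compound 2 `N#CC1=C(NCC(=O)O)N(c2ccccc2)C(=O)N2CCCCC(N3CCCC3)C12` — 89.2%
compound 3 `COc1ccc(N/C=N/C2=C(C#N)C3C(N4CCCC4)CCCCN3C(=O)N2c2ccccc2)cc1` — 50.2%

All three were run in a functional assay on the whole organism (strain albino) for inhibition, with Rattus norvegicus as the target, read by paw edema, with stated times of 1 h and 3 h, at a dose of 20 mmol/kg by the intraperitoneal route; on this read-out lower numbers stand for a weaker effect and higher numbers for a stronger effect at the one dose given. Compound 3 stands second highest of the three numbers: its nearest neighbour is compound 1, with a number 14.9 percentage points higher from compound 1 to compound 3 (beyond the scatter), and its furthest is compound 2, with a number 39 percentage points lower from compound 2 to compound 3 (beyond the scatter). Both of those steps exchange the whole group on the double-bonded ring carbon, and compound 2 shows that a carboxy on that side of the core carries the highest number seen, as a number 53.9 percentage points higher from compound 1 to compound 2 (beyond the scatter) makes plain.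

Compound 4 `COc1ccc(/C=N/C2=C(C#N)C3C(N4CCCC4)CCCCN3C(=O)N2c2ccccc2)cc1` keeps the 4-methoxyphenyl part of compound 3 and alters only the link to it: 4-methoxyphenyl in place of (4-methoxyphenyl)amino on a carbon with a double bond to nitrogen. Among the compounds with values here, no measured step removes an amino link of this kind while keeping the aryl group, so the three steps bear only loosely on it; the two that touch this carbon were modest and large, and each changed far more than one nitrogen. A smaller step than either is therefore expected, with the direction uncertain. Compound 4 is expected to give 44%, between 25% and 63%. The expected step is a number 6.2 percentage points lower from compound 3 to compound 4 (within the scatter), within the scatter or only a little beyond it.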

Compound 4, a percentage reported as inhibition, in the whole organism at one dose (the size of the read-out at that dose, not a potency): 75.3%
The estimate for compound 4 lay 31.3 percentage points below the measured number, and the stated range ends below it.
By their numbers in this assay, from the lowest: compound 1; then compound 3; then compound 4; then compound 2.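

Dropping the amino link while keeping the 4-methoxyphenyl group gives a number 25.1 percentage points higher from compound 3 to compound 4 (beyond the scatter) and so moves the read-out beyond the scatter: on a carbon with a double bond to nitrogen, this one change matters in its own right. Within the data shown here, a carboxy is also not the only group on the double-bonded ring carbon that gives a high number, as a number 40 percentage points higher from compound 1 to compound 4 (beyond the scatter) shows, although a number 13.9 percentage points lower from compound 2 to compound 4 (beyond the scatter) still leaves compound 2 on top. No measured evidence accounts for the rise from the amino link's removal.

As far as these compounds go, it remains open whether the same gain appears with phenyl or 4-chlorophenyl in place of 4-methoxyphenyl. A methylamino link could also show whether the hydrogen on the amino nitrogen or the nitrogen itself goes with the lower number.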